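Adding Chlorine to the Benzyl Group of Compound 3

The source may report more compounds than this note shows. Statements on the series, on what has been measured and on what is new or still open speak of the compounds shown alone.

- Compound 1 `COc1ccc(CSc2nnc([C@@H](C)c3ccc4cc(OC)ccc4c3)n2-c2ccc(Cl)cc2)cc1`: <= 400000 nM, a limit and not a number
- Compound 2 `COc1ccc2cc([C@H](C)c3nnc(SCc4ccc(Cl)cc4)n3-c3ccc(Cl)cc3)ccc2c1`: 110000 nM
- Compound 3 `COc1ccc2cc([C@H](C)c3nnc(SCc4ccccc4)n3-c3ccc(Cl)cc3)ccc2c1`: 50400 nM

These values come from a functional assay on LNCaP cells (Homo sapiens) for cytotoxicity, read by MTT assay; on this read-out lower numbers stand for stronger inhibition and higher numbers for weaker inhibition. Of the two true numbers, the lower belongs to compound 3, at 50400 nM.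

The next candidate is compound 4 `COc1ccc2cc([C@H](C)c3nnc(SCc4c(Cl)cccc4Cl)n3-c3ccc(Cl)cc3)ccc2c1`, which turns benzyl into 2,6-dichlorobenzyl: 2,6-dichlorophenyl in place of phenyl on a saturated chain carbon bound to a sulfur.

Compound 1 has only a limit, so steps from it have no readable size. Within the data shown here, the one usable guide is a 2.2-fold lower number from compound 2 to compound 3 (0.34 log units; beyond the scatter), a change of chloro to hydrogen on an aromatic carbon. Read in reverse, this single pair links chloro with the higher number. Compound 4 also brings in chlorine, so a modest rise in this assay is expected, though one pair is thin support and the range must stay wide. The expected change is a 1.7-fold higher number from compound 3 to compound 4 (0.23 log units; within the scatter). For compound 4 the estimated value is 85000 nM, with an expected range from 30000 nM to 240000 nM.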

Compound 4, half-maximal inhibitory concentration: > 400000 nM
Compound 4: no number, only a limit; the forecaster's own chance of this, stated with the estimate: 20%; middle value at least 4.7-fold (0.67 log units) from the limit.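

At this place, on a saturated chain carbon bound to a sulfur, putting 2,6-dichlorophenyl in place of phenyl gives an at least 7.9-fold higher number from compound 3 to compound 4 (0.89 log units; beyond the scatter) in this assay. Starting from 4-chlorophenyl, the same group still gives an at least 3.6-fold higher number from compound 2 to compound 4 (0.56 log units; beyond the scatter), so at this place 2,6-dichlorophenyl goes with a higher number than 4-chlorophenyl does, and the chlorine penalty is not one fixed amount. Compound 4 has only a limit and not a number, so both steps are minimum sizes because of that limit: the limit of > 400000 nM in this assay, at which 1 of the 4 values shown sits.

Compound 1 also has only a limit and not a number. The remaining step reads only as a number no lower from compound 1 to compound 4 (the limit leaves the size open), and its size cannot be read.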